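The compounds below may be only part of what the source reports. "The series", "measured", "known", "first", "only" and "open" are said of these compounds alone.

Compound 1 `COc1ncc(-c2ccc3c(c2)NC(=O)CO3)cc1NS(=O)(=O)c1ccc(F)cc1` gives 26300 nM in a functional assay on A-375 cells (Homo sapiens) for antiproliferative activity, read by MTT assay, with a stated time of 72 h; on this read-out lower numbers stand for stronger inhibition and higher numbers for weaker inhibition. Compound 2 `COc1cccc(N2C(=O)COc3ccc(-c4cnc(OC)c(NS(=O)(=O)c5ccc(F)cc5)c4)cc32)c1` reaches only a limit of this assay, > 40000 nM. The change from compound 2 to compound 1 is hydrogen in place of 3-methoxyphenyl on an amide-type nitrogen in a ring, and it produced an at least 1.5-fold lower number from compound 2 to compound 1 (0.18 log units; that floor lies within the scatter); the floor of that step rests on (the limit of > 40000 nM in this assay, at which 1 of the 3 values shown sits). Compound 3 `COc1cccc(N2C(=O)COc3ccc(-c4ccc(O)cc4)cc32)c1` gives 30400 nM in this assay, and its value and that of compound 1 lie within the usual scatter of each other. How the core of compound 3 differs from that of compound 2 is not broken down here. Compound 4 `O=C1COc2ccc(-c3ccc(O)cc3)cc2N1` is still to be measured in this assay; it differs from compound 3 by hydrogen in place of 3-methoxyphenyl on an amide-type nitrogen in a ring, the same change made at the same place as from compound 2 to compound 1. Within the data shown here, the step expected is a 1.5-fold lower number from compound 3 to compound 4 (0.18 log units; within the scatter), resting on the single earlier step of an at least 1.5-fold lower number from compound 2 to compound 1 (0.18 log units; that floor lies within the scatter), whose floor lies within the scatter. Compound 4 is estimated at 20000 nM, between 8000 nM and 40000 nM.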

Compound 4, half-maximal inhibitory concentration: > 40000 nM
Compound 4: only a limit was reported; the forecaster's own chance of this, stated with the estimate: 15%; at least 2.0-fold (0.30 log units) between middle value and limit.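

In this assay, putting hydrogen in place of 3-methoxyphenyl on the amide-type nitrogen gives an at least 1.3-fold higher number from compound 3 to compound 4 (0.11 log units; that floor lies within the scatter). Set beside the same change on the other core, this does not show that the change carries over from one core to another, and it does not show that it fails to: the same change on two cores in this assay, an at least 1.5-fold lower number (0.18 log units; that floor lies within the scatter) from compound 2 to compound 1 and an at least 1.3-fold higher number (0.11 log units; that floor lies within the scatter) from compound 3 to compound 4; the limit leaves it open whether they differ. Neither step has a firm size, and that floor comes from values that are limits of the assay and not numbers: the limit of > 40000 nM in this assay, at which 2 of the 4 values shown sit.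

The compounds shown leave open how other groups on that nitrogen would behave, such as methyl, benzyl or a longer chain ending in an amine. They also leave open whether any such group would give a clear step on both cores.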